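Replacing a Small Saturated Ring with a Larger One

The source may hold more compounds than are shown below. What is called first, only, known or untested is meant among the compounds shown, and "the series" means these compounds.

Among the measured compounds shown here, the two compounds measured so far share one core. Compound 1 `Oc1ccc(CNc2cc(C(F)(F)F)cc3[nH]ncc23)cc1` gives 81% in an assay for inhibition of Indoleamine 2,3-dioxygenase 1 (Homo sapiens), with stated times of 10 min and 60 min, tested at 100 uM; a lower number here means a weaker effect, a higher number a stronger effect of the compound at the concentration tested. For the measured compounds named here, compound 2 `FC(F)(F)c1cc(NCC2CNC2)c2cn[nH]c2c1` gives 22% in this assay, which is the lowest of the two numbers, and the only step recorded, a number 59 percentage points lower from compound 1 to compound 2 (beyond the scatter), is a large loss that goes with exchanging 4-hydroxyphenyl for azetidin-3-yl on a saturated chain carbon bound to a nitrogen on an aromatic ring.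

Compound 3 `FC(F)(F)c1cc(NC[C@@H]2CCCCN2)c2cn[nH]c2c1` has not yet been measured. It differs from compound 2 as follows: piperidin-2-yl in place of azetidin-3-yl on a saturated chain carbon bound to a nitrogen on an aromatic ring. Going by the values given here, the one measured step does not contain this change; it only shows that a saturated ring with one nitrogen in this place sits far below the 4-hydroxyphenyl of compound 1. Compound 3 keeps a saturated ring with one nitrogen at the same place, so no move beyond the scatter is expected in this assay on the evidence at hand. Compound 3 is therefore estimated at 25%, within a range from 5% to 55%, a step of a number 3 percentage points higher from compound 2 to compound 3 (within the scatter) that is expected to stay within the scatter.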

Compound 3, a percentage reported as inhibition, at one concentration (the size of the read-out at that concentration, not a potency): 81%
Compound 3: the middle estimate sits 56 percentage points below what was measured, and the stated range ends below it.
By their numbers in this assay, from the lowest: compound 2; then compounds 1 and 3 (each within the scatter of the next).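

Exchanging azetidin-3-yl for piperidin-2-yl gives a number 59 percentage points higher from compound 2 to compound 3 (beyond the scatter) in this assay, so the low number of compound 2 cannot be put down simply to having a saturated ring with one nitrogen on a saturated chain carbon bound to a nitrogen on an aromatic ring. The aromatic group is not needed for a high number in this pair either, as piperidin-2-yl in place of 4-hydroxyphenyl gives no change at the digits printed from compound 1 to compound 3 (within the scatter), which means that the identity of the saturated ring matters at this position, with one such ring matching the 4-hydroxyphenyl of compound 1 and another falling far short of it. No measurement at hand explains the gap between the two saturated rings.

The step from compound 2 to compound 3 changes the ring size and the ring carbon that carries the chain, and it adds a defined stereocentre, so these three changes cannot be separated here, and a pyrrolidin-2-yl ring, a piperidin-3-yl ring, the opposite mirror-image form of piperidin-2-yl or an open-chain amine would each help to pull them apart. Each number is also a read-out at one concentration, so compound 1 and compound 3 can be compared only by the size of their effect at that concentration.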